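A few compounds are considered here, and "the series" means these few. Any claim that something is new, unique, unknown or untested is made for them only; others in the source may bear on it.

Compound 3, `C=CCN(Cc1ccc2nc(C)[nH]c(=O)c2c1)c1ccc(C(=O)N[C@@H](CCC(=O)O)C(=O)O)c(F)c1`, gives 76 nM in an assay on isolated protein for inhibition of Thymidylate synthase (Mus musculus); on this read-out lower numbers stand for stronger inhibition and higher numbers for weaker inhibition. Of the three compounds measured there, compound 3 carries the lowest number. Compound 2, `Cc1nc2ccc(CN(CC(N)=O)c3ccc(C(=O)N[C@@H](CCC(=O)O)C(=O)O)c(F)c3)cc2c(=O)[nH]1`, gives 1340 nM, and compound 1, `C=CCN(Cc1ccc2nc(C)[nH]c(=O)c2c1)c1ccc(C(=O)N[C@@H](CCC(=O)O)C(=O)O)cc1F`, gives 5160 nM. Among the compounds with values here, the one single-point step that has been measured, an 18-fold lower number from compound 2 to compound 3 (1.25 log units; beyond the scatter), concerns the vinyl in place of carbamoyl on the saturated chain carbon bound to the nitrogen on the aromatic ring, not the fluoro.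

Compound 4, `C=CCN(Cc1ccc2nc(C)[nH]c(=O)c2c1)c1ccc(C(=O)N[C@@H](CCC(=O)O)C(=O)O)cc1`, differs from compound 3 by hydrogen in place of fluoro on an aromatic carbon. Within the data shown here, no measured step touches this fluoro; compound 1 and compound 3 both carry a fluoro, but on different aromatic carbons, and their values are far apart, so they do not show what removing the fluoro alone does. With nothing bearing directly on the change, the expectation for compound 4 rests on the value of compound 3, 76 nM, and is that the number moves little.

Compound 4 is therefore expected to give 120 nM in this assay, in a range from 40 nM to 350 nM. The step this estimate means, a 1.6-fold higher number from compound 3 to compound 4 (0.20 log units; within the scatter), is expected to lie within the scatter, with the range open to a modest weakening.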

Compound 4, half-maximal inhibitory concentration: 480 nM
Beside the measured number, compound 4's estimate is 4.0-fold (0.60 log units) below it, and the stated range ends below it.
By their numbers in this assay, from the lowest: compound 3; then compound 4; then compound 2; then compound 1.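

In this assay, hydrogen in place of the fluoro ortho to a (1,3-dicarboxypropyl)carbamoyl group gives a 6.3-fold higher number from compound 3 to compound 4 (0.80 log units; beyond the scatter), so this fluoro is not a neutral passenger on the shared core. The same kind of change on the other fluoro-bearing aromatic carbon runs the opposite way, with an 11-fold lower number from compound 1 to compound 4 (1.03 log units; beyond the scatter). Among these three compounds, then, the fluoro goes with the lower number when it sits ortho to the (1,3-dicarboxypropyl)carbamoyl group and with the higher number on the other carbon, with compound 4, which has no fluoro, falling between them. No measurement available here accounts for this difference between the two carbons.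

As far as these compounds go, what a chloro or a methoxy group would do on the carbon ortho to the (1,3-dicarboxypropyl)carbamoyl group stays open. It is also open whether the fluoro there counts for as much when the chain on the nitrogen is the carbamoyl-bearing one of compound 2, since no counterpart of compound 2 without the fluoro is shown.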